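Compound 3: 2,6-difluorophenyl in place of 2-methoxyphenyl

The compounds below may be only part of what the source reports. "The series", "measured", "known", "first", "only" and "open" are said of these compounds alone.

Measured in a functional assay on CHO cells for positive allosteric modulation of metabotropic glutamate receptor 2 (Homo sapiens), with a stated time of 30 min; on this read-out higher numbers stand for an effect only at larger amounts of compound and lower numbers for an effect already at smaller amounts:
Compound 1 `N#Cc1c(N2CCC(c3ccc(F)cc3)CC2)ccn(CC2CC2)c1=O` gives 89 nM.
Compound 2 `COc1ccccc1C1CCN(c2ccn(CC3CC3)c(=O)c2C#N)CC1` gives 35 nM.

Among the measured compounds shown here, compound 2 stands at the lowest of the two numbers; the only other compound, compound 1, sits above it by the single measured step, a 2.5-fold lower number from compound 1 to compound 2 (0.41 log units; beyond the scatter), which came with 2-methoxyphenyl in place of 4-fluorophenyl on a saturated ring carbon.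

Compound 3 `N#Cc1c(N2CCC(c3c(F)cccc3F)CC2)ccn(CC2CC2)c1=O` differs from compound 2 by 2,6-difluorophenyl in place of 2-methoxyphenyl on a saturated ring carbon. For the measured compounds named here, no measured step exchanges these two groups; the one step available touches the same saturated ring carbon but a different pair of groups, and it was modest. The only other fluorine-bearing ring here sits on compound 1, which gives 89 nM in this assay . A small shift toward higher numbers, close to the scatter, is therefore expected for compound 3, namely a 1.6-fold higher number from compound 2 to compound 3 (0.20 log units; within the scatter). Compound 3 is estimated at 55 nM, with a range from 20 nM to 150 nM.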

Compound 3, half-maximal effective concentration: 31 nM
Estimate against measurement, compound 3: 1.8-fold (0.25 log units) above; low and high end bracket the measured number.
By their numbers in this assay, from the lowest: compounds 3 and 2 (each within the scatter of the next); then compound 1.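

In this assay, the saturated ring carbon accepts 2,6-difluorophenyl in place of 2-methoxyphenyl with a 1.1-fold lower number from compound 2 to compound 3 (0.05 log units; within the scatter), so a group with no hydrogen-bond acceptor and no oxygen can stand here in place of one with an acceptor, without a change that can be told from the scatter. Fluorine on the aromatic ring does not by itself fix the number, since the change from 4-fluorophenyl to 2,6-difluorophenyl gives a 2.9-fold lower number from compound 1 to compound 3 (0.46 log units; beyond the scatter). Nothing at hand explains either step.

A 2-fluorophenyl group, with its single fluorine, would show whether one fluorine is enough to give a number like that of compound 3. On these data alone, it also remains open how this position would respond to an aromatic ring bearing an amine or a carboxylic acid.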